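The source may hold more compounds than are shown below. What is called first, only, known or untested is meant among the compounds shown, and "the series" means these compounds.

Compound 1 `COc1cccc(C2(CNC(=O)Nc3c(C(C)C)cccc3C(C)C)CCCC2)c1`: 13 nM in an assay on microsomes for inhibition of acyl-CoA:cholesterol acyltransferase (Oryctolagus cuniculus); on this read-out higher numbers stand for weaker inhibition and lower numbers for stronger inhibition. Compound 2 `CC(C)c1cccc(C(C)C)c1NC(=O)NCC1(c2ccc(NCCO)cc2)CCCC1`: 25 nM in this assay.

Among the compounds with values here, compound 2 gives the higher of the two numbers in this assay; its only neighbour is compound 1, and the step of a 1.9-fold higher number from compound 1 to compound 2 (0.28 log units; within the scatter) lies within the scatter. Compound 3 `Cc1ccc(C2(CNC(=O)Nc3c(C(C)C)cccc3C(C)C)CCCC2)c(C)c1` differs from compound 2 by 2,4-dimethylphenyl in place of 4-((2-hydroxyethyl)amino)phenyl on a saturated ring carbon. Within the data shown here, the one measured step that bears on this place, a 1.9-fold higher number from compound 1 to compound 2 (0.28 log units; within the scatter), also exchanged the aryl group on that saturated ring carbon and stayed within the scatter, so no step beyond the scatter is expected in this assay. Compound 3 is therefore expected at 16 nM, between 5 nM and 50 nM. The expected step is a 1.6-fold lower number from compound 2 to compound 3 (0.19 log units; within the scatter).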

Compound 3, half-maximal inhibitory concentration: 50 nM
The estimate for compound 3 lay 3.1-fold (0.49 log units) below the measured number; the range from low to high includes it.
By their numbers in this assay, from the lowest: compounds 1, 2 and 3 (each within the scatter of the next, the first and the last beyond it).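

In this assay, exchanging the aryl group on the saturated ring carbon now gives its first step beyond the scatter, though a modest one: 2,4-dimethylphenyl in place of 3-methoxyphenyl gives a 3.8-fold higher number from compound 1 to compound 3 (0.59 log units; beyond the scatter). Replacing 4-((2-hydroxyethyl)amino)phenyl with the same group stays within the scatter, at a 2.0-fold higher number from compound 2 to compound 3 (0.30 log units; within the scatter), although the leaving group has hydrogen-bond donors and acceptors and the entering group has none. No evidence is at hand to explain these steps. The compounds shown leave open how a 4-methylphenyl or 2-methylphenyl group would read at this place, which would separate the two methyl groups. They also leave open how a carboxylic acid at the end of the hydroxyethyl chain would read.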